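A few compounds are considered here, and "the series" means these few. Any claim that something is new, unique, unknown or untested is made for them only; others in the source may bear on it.

Compound 1 `C/C=C/C(=O)Nc1cccc(Cn2nc(-c3ccc(Oc4ccccc4)cc3)cc2C(=O)O)c1` is the weakest of the three measured compounds in a functional assay on Maver1 cells (Homo sapiens) for inhibition, read by luminescence and CellTiter-Glo, with a stated time of 72 h (on this read-out higher numbers stand for weaker inhibition and lower numbers for stronger inhibition), where compound 1 gives 31600 nM. Compound 2 `C/C=C/C(=O)Nc1cccc(Cn2nc(-c3ccc(Oc4ccccc4)cc3)cc2CO)c1` gives 8100 nM in this assay, and compound 3 `C=CC(=O)Nc1cccc(Cn2nc(-c3ccc(Oc4ccccc4)cc3)cc2CO)c1` gives 6700 nM. The step from compound 1 to compound 2 is a 3.9-fold lower number from compound 1 to compound 2 (0.59 log units; beyond the scatter), a change at the shared core. The step from compound 2 to compound 3 is a 1.2-fold lower number from compound 2 to compound 3 (0.08 log units; within the scatter), which alters only the chain on the carbonyl carbon of the amide.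

Compound 4 `O=C(CCl)Nc1cccc(Cn2nc(-c3ccc(Oc4ccccc4)cc3)cc2C(=O)O)c1` differs from compound 1 in one place: chloromethyl in place of prop-1-en-1-yl on a carbonyl carbon. Within the data shown here, the only measured step touching this part of the molecule is a 1.2-fold lower number from compound 2 to compound 3 (0.08 log units; within the scatter), and it stayed inside the usual scatter. Among the measured compounds shown here, no measured compound carries a chloromethyl group, and no measured step changes the amide chain while the carboxy group is kept, so the expectation for compound 4 rests on a single small step. For compound 4 the estimate in this assay is therefore a step of about a 1.1-fold lower number from compound 1 to compound 4 (0.05 log units; within the scatter), too small to count as a real change. Compound 4 is expected to give around 28000 nM in this assay, with a range from 9000 nM to 90000 nM.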

Compound 4, half-maximal inhibitory concentration: 4700 nM
The estimate for compound 4 lay 6.0-fold (0.78 log units) above the measured number; the whole stated range lies above it.
By their numbers in this assay, from the lowest: compounds 4, 3 and 2 (each within the scatter of the next); then compound 1.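

The carbonyl carbon of the amide is not a position where changes are always silent. Among these compounds, replacing prop-1-en-1-yl with chloromethyl in this assay gives a 6.7-fold lower number from compound 1 to compound 4 (0.83 log units; beyond the scatter), whereas the only earlier change at this position, made with hydroxymethyl rather than carboxy on the shared core, gave a 1.2-fold lower number from compound 2 to compound 3 (0.08 log units; within the scatter). So the carboxy compounds can respond to a change in this chain, and the small earlier step did not predict what a different group would do here, although no evidence is available to explain the difference.

The change also swaps more than one feature at once, since the chain loses its double bond and gains a chlorine, so the compounds shown cannot separate these two differences; a plain ethyl chain or a bromomethyl group on the same carbonyl carbon would help to tell them apart. As far as these compounds go, it also remains open whether chloromethyl would give a step of similar size on the hydroxymethyl compounds, so the result cannot yet be read as a general rule for this position.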